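Lengthening the allyl chain of compound 2

The source may report more compounds than this note shows. Statements on the series, on what has been measured and on what is new or still open speak of the compounds shown alone.

Going by the values given here, compound 2 `C=CCn1c(N[C@@H]2C[C@H](c3ccccc3)CN(C)C2)nc2cc[nH]c2c1=O` gives 2.2 degrees C in an assay on isolated protein for binding affinity to histone acetyltransferase KAT2B (Homo sapiens), read by fluorescence, tested at 10 uM (a higher number here means that the compound stabilises the target more against heat, a lower number that the compound stabilises the target less), and stands lowest of the two numbers measured so far; compound 1 `CN1C[C@H](Nc2nc3cc[nH]c3c(=O)n2C)C[C@H](c2ccccc2)C1` gives 6.3 degrees C. The one recorded step, a number 4.1 degrees C lower from compound 1 to compound 2 (beyond the scatter), came from a vinyl in place of hydrogen on a saturated chain carbon bound to an aromatic nitrogen. Compound 3 `CC=CCn1c(N[C@@H]2C[C@H](c3ccccc3)CN(C)C2)nc2cc[nH]c2c1=O` carries the change (methyl in place of hydrogen on a double-bonded chain carbon bound to a double-bonded chain carbon), which, cut one bond further out, reads allyl to but-2-en-1-yl. Among the compounds with values here, the only measured step concerns the same chain and was large, but no measured pair shows what adding to the far end of that chain does. A methyl there is expected to move the number little, and the step of a number 0.70 degrees C lower from compound 2 to compound 3 (within the scatter) is estimated to stay within the scatter or go slightly further down. Compound 3 is therefore expected to give 1.5 degrees C, with a range from -1 degrees C to 4 degrees C.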

Compound 3, shift of the target's melting temperature: 1.5 degrees C
Estimate against measurement, compound 3: no gap at the digits printed; low and high end bracket the measured number.
By their numbers in this assay, from the lowest: compounds 3 and 2 (each within the scatter of the next); then compound 1.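

In this assay, the step from allyl to but-2-en-1-yl gives a number 0.70 degrees C lower from compound 2 to compound 3 (within the scatter), so a methyl on this double-bonded chain carbon brings no change that the scatter can separate. Measured from the shared parent, the longer chain gives a number 4.8 degrees C lower from compound 1 to compound 3 (beyond the scatter), which stands with a number 4.1 degrees C lower from compound 1 to compound 2 (beyond the scatter) as a second large step in the same direction, so the low numbers hold for both alkenyl chains. Nothing measured here accounts for either step.

As far as these compounds go, whether the double bond matters remains open: a saturated propyl chain in place of allyl would separate it from chain length. Also open, from the compounds shown here alone, is whether a chain ending in an amine or a hydroxyl group would come closer to compound 1, at 6.3 degrees C.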